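Aryl change on the sulfonyl sulfur, compound 2 to compound 3

This account rests on a few compounds, and the source may have more. Where it says the series, first, only, none or still open, it means among the compounds named here.

Measured in a functional assay on HEK293 cells (Homo sapiens) for cytotoxicity; on this read-out higher numbers stand for lower toxicity in this test and lower numbers for higher toxicity in this test:
- Compound 1 `COc1ccc([C@H]2CC(=O)N(c3cccc(C#N)c3)C2)cc1OC1CCCC1`: > 10000 nM (a limit)
- Compound 2 `COc1ccc(S(=O)(=O)Nc2cccc(N3C[C@@H](c4ccc(OC)c(OC5CCCC5)c4)CC3=O)c2)cc1`: > 10000 nM (a limit)

Compound 2 gives no number, only a limit. For the measured compounds named here, neither measured compound has a number, and the series so far rests on (the limit of > 10000 nM in this assay, at which 2 of the 2 values shown sit).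

Compound 3 `COc1ccc([C@H]2CC(=O)N(c3cccc(NS(=O)(=O)c4cccc(Cl)c4)c3)C2)cc1OC1CCCC1` has 3-chlorophenyl in place of 4-methoxyphenyl on a sulfonyl sulfur.

Going by the values given here, the one measured step is a step that the two limits leave unreadable from compound 1 to compound 2. It offers no size to carry over, and no change on the sulfonyl aryl group has been measured. No step beyond the scatter is expected in this assay, and no direction can be assigned. This expectation rests on compound 2, whose > 10000 nM is a limit. The expected step is a step that the limit leaves unreadable from compound 2 to compound 3. For compound 3 the estimated value is 15000 nM, with an expected range of 7000 nM to 30000 nM, and a further limit is the likeliest report.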

Compound 3, half-maximal cytotoxic concentration: > 10000 nM
Compound 3: only a limit was reported; the forecaster's own chance of this, stated with the estimate: 85%; the middle value does not contradict the limit.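

In this assay compound 3 gives > 10000 nM, a limit, so its steps from compound 1 and compound 2 cannot be read. Still open is the size and direction of any effect of these changes on the sulfonyl aryl group or the cyano position, with the series resting on one figure: the limit of > 10000 nM in this assay, at which 3 of the 3 values shown sit.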